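The source may report more compounds than this note shows. Statements on the series, on what has been measured and on what is new or still open speak of the compounds shown alone.

Working notes on the series in an assay on isolated protein for binding affinity to 5-hydroxytryptamine receptor 3A (Homo sapiens); a higher number here means a weaker inhibitor, a lower number a stronger inhibitor.

Three compounds of the shared core carry numbers. Compound 1 `CS(=O)(=O)N1CCN(CC(O)CN2CCC(CNC(=O)c3cccc4[nH]cnc34)CC2)CC1` gives 50100 nM. Compound 2 `CC(C)(C)c1nc2c(C(=O)NCC3CCN(CC(O)CN4CCN(S(C)(=O)=O)CC4)CC3)cccc2[nH]1` gives 39800 nM. Compound 3 `CC(C)c1nc2c(C(=O)NCC3CCN(CCN4CCN(S(C)(=O)=O)CC4)CC3)cccc2[nH]1` gives 100000 nM, the highest of the three numbers: against compound 1 the gap is within the scatter, and against compound 2 it is larger and lies beyond it. Among the compounds with values here, compounds 1 and 3 differ in the substituent on the core and in the hydroxyl on the chain, so no single-point step joins them. Within the data shown here, the one single-point step, a 1.3-fold lower number from compound 1 to compound 2 (0.10 log units; within the scatter), shows that a tert-butyl in place of hydrogen on an aromatic carbon hardly moves the read-out.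

Compound 4 `COC(=O)N(C)CC(O)CN1CCC(CNC(=O)c2cccc3[nH]c(C(C)C)nc23)CC1` is not yet measured. It differs from compound 3 by 1-hydroxy-2-((methoxycarbonyl)(methyl)amino)ethyl in place of (4-(methylsulfonyl)piperazin-1-yl)methyl on a saturated chain carbon bound to an amine nitrogen in a ring. Among the measured compounds shown here, no measured step touches this part of the molecule; the only step in hand concerns the aromatic substituent and was within the scatter. With nothing that bears on the chain end, the expectation for compound 4 is a step of a 1.3-fold lower number from compound 3 to compound 4 (0.10 log units; within the scatter), that is, no change beyond the scatter. The number expected for compound 4 is therefore 80000 nM, with a range from 25000 nM to 300000 nM.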

Compound 4, inhibition constant: 50100 nM
Beside the measured number, compound 4's estimate is 1.6-fold (0.20 log units) above it, and the stated range covers the measured number.
By their numbers in this assay, from the lowest: compounds 2, 1, 4 and 3 (each within the scatter of the next, the first and the last beyond it).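

In this assay, within the data shown here, the exchange of (4-(methylsulfonyl)piperazin-1-yl)methyl for 1-hydroxy-2-((methoxycarbonyl)(methyl)amino)ethyl gives a 2.0-fold lower number from compound 3 to compound 4 (0.30 log units; within the scatter) and is the first reading at this position, on a saturated chain carbon bound to an amine nitrogen in a ring, as the earlier step concerned only the aromatic substituent. The entering group has no ring and the leaving group has a six-membered non-aromatic ring with 2 hetero atoms, and the sulfur of the leaving group is also lost, yet the step stays within the scatter, so in this pair the read-out tolerates a large change in the chain end. No measurement in hand bears on the reason for this result.

The entering group also brings a hydroxyl, and this single step cannot separate the share of that hydroxyl from the share of the rest of the chain end. On these data alone, the effect of other chain ends at this position, such as a primary amine, a carboxylic acid or a longer alkyl chain, remains open, as does whether any group here can shift the number beyond the scatter.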